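Removing the phenoxycarbonyl group from compound 1

This account rests on a few compounds, and the source may have more. Where it says the series, first, only, none or still open, it means among the compounds named here.

Compound 1 `COc1ccc(S(=O)(=O)N2CCc3cccc(NC(=O)Oc4ccccc4)c32)cc1`: > 10000 nM
Compound 2 `COc1ccc(S(=O)(=O)N2CCc3cc(Br)cc(NC(=O)c4ccco4)c32)cc1`: 89 nM

In a functional assay on KB cells (Homo sapiens) for cytotoxicity (a lower number here means a stronger inhibitor, a higher number a weaker inhibitor), compound 1 gives > 10000 nM, which is a limit and not a number. Compound 3 `COc1ccc(S(=O)(=O)N2CCc3cccc(N)c32)cc1` has hydrogen in place of phenoxycarbonyl on a nitrogen on an aromatic ring. Among the compounds with values here, no measured pair shows this change directly. Compound 2 reads 89 nM, so a strong reading is possible among these compounds, although compound 2 differs in other groups too. A modest gain in potency is expected, and the estimated step is an at least 4.0-fold lower number from compound 1 to compound 3 (0.60 log units; beyond the scatter). For compound 3 the expected value is 2500 nM, with an estimated range from 300 nM to 10000 nM.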

Compound 3, half-maximal inhibitory concentration: 2800 nM
The estimate for compound 3 lay 1.1-fold (0.05 log units) below the measured number, within the range that was stated.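

With the phenoxycarbonyl group gone, the free amino compound 3 gives a real number for this position in this assay, and the change makes an at least 3.5-fold lower number from compound 1 to compound 3 (0.55 log units; beyond the scatter). So this nitrogen tolerates losing the whole group, and the bare amine is the more potent form of this pair. The step is only a lower bound, and its true size cannot be read: the limit of > 10000 nM in this assay, at which 1 of the 3 values shown sits.

From the compounds shown here alone, it remains open whether a smaller group on this nitrogen, such as acetyl or methyl, would read closer to compound 3 or to compound 1. The pair also cannot tell whether the phenyl ring or the carbonyl accounts for the difference.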